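Methyl in place of 4-methylphenyl on the shared core

A few compounds are considered here, and "the series" means these few. Any claim that something is new, unique, unknown or untested is made for them only; others in the source may bear on it.

Compound 3 `Cc1ccc(-c2c3ccc4ccccc4c3nc3c2c(C)nc2c4ccccc4ccc32)cc1` gives 72200 nM in a functional assay on HeLa cells (Homo sapiens) for cytotoxicity, read by MTT assay, with a stated time of 48 h (a lower number here means a stronger inhibitor, a higher number a weaker inhibitor), the highest of the two numbers shown. Compound 2 `Cc1nc2c3ccccc3ccc2c2nc3c(ccc4ccccc43)c(-c3ccccc3S)c12` gives 3190 nM in this assay. Compound 1 `Cc1nc2c3ccccc3ccc2c2nc3c(ccc4ccccc43)c(-c3ccccc3Cl)c12` reports only a limit in this assay, > 80000 nM. Compound 4 `Cc1nc2c3ccccc3ccc2c2nc3c(ccc4ccccc43)c(C)c12` differs from compound 3 by methyl in place of 4-methylphenyl on an aromatic carbon. Among the compounds with values here, no measured step removes the aryl ring altogether. Of the two steps that reach compound 3, an at least 1.1-fold lower number from compound 1 to compound 3 (0.04 log units; that floor lies within the scatter) shows one aryl swapped for another without change, whereas a 23-fold higher number from compound 2 to compound 3 (1.35 log units; beyond the scatter) shows the large change tied to the sulfanyl group. Compound 4 carries no sulfanyl, so no step beyond the scatter is expected from compound 3 to compound 4, as in an at least 1.1-fold lower number from compound 1 to compound 3 (0.04 log units; that floor lies within the scatter). Compound 4 is estimated at 70000 nM in this assay, within 20000 nM to 250000 nM, a step of a 1.0-fold lower number from compound 3 to compound 4 (0.01 log units; within the scatter).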

Compound 4, half-maximal inhibitory concentration: > 80000 nM
Compound 4: no number, only a limit (the forecaster's own chance of this, stated with the estimate: 40%); at least 1.1-fold (0.05 log units) between middle value and limit.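

Compound 4 shows that in this assay the aryl ring at this place, opposite the ring nitrogen, can give way to methyl with no measurable gain: compound 4 gives > 80000 nM, which is a limit and not a number. Replacing 4-methylphenyl leaves an at least 1.1-fold higher number from compound 3 to compound 4 (0.04 log units; that floor lies within the scatter), whereas replacing 2-sulfanylphenyl gives an at least 25-fold higher number from compound 2 to compound 4 (1.39 log units; beyond the scatter), so among these groups only 2-sulfanylphenyl sets a compound apart. The remaining step cannot be read, and the limit recurs across the series: the limit of > 80000 nM in this assay, at which 2 of the 4 values shown sit.

As far as these compounds go, whether a hydroxyl or an amine on the phenyl ring, in place of sulfanyl, would also give a lower number remains open. So does whether sulfanyl directly on this aromatic carbon, without the phenyl ring, would do so.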